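A few compounds are considered here, and "the series" means these few. Any claim that something is new, unique, unknown or untested is made for them only; others in the source may bear on it.

Measured compounds in a functional assay on RAW264.7 cells (Mus musculus) for inhibition, read by Griess assay, with stated times of 2 h and 24 h; a higher number here means a weaker inhibitor, a lower number a stronger inhibitor:

compound 1 `CCn1cc(COc2cc(O)c3c(c2)O[C@H](c2ccc(OC)c(O)c2)CC3=O)nn1`: 15000 nM
compound 2 `COc1ccc([C@@H]2CC(=O)c3c(O)cc(OCc4cn(C5CCCC5)nn4)cc3O2)cc1O`: 10500 nM
compound 3 `COc1ccc([C@@H]2CC(=O)c3c(O)cc(OCc4cn(Cc5ccc(C(F)(F)F)cc5)nn4)cc3O2)cc1O`: 17700 nM

Compound 3 carries the highest of the three numbers in this assay, but its distances to the others are small: a 1.2-fold higher number from compound 1 to compound 3 (0.07 log units; within the scatter) and a 1.7-fold higher number from compound 2 to compound 3 (0.23 log units; within the scatter) both fall within the scatter, as does a 1.4-fold lower number from compound 1 to compound 2 (0.15 log units; within the scatter). On the numbers shown the three substituents on the aromatic nitrogen are therefore indistinguishable.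

Compound 4 `CCCn1cc(COc2cc(O)c3c(c2)O[C@H](c2ccc(OC)c(O)c2)CC3=O)nn1` is the next member. The change from compound 3 is ethyl in place of 4-(trifluoromethyl)phenyl on a saturated chain carbon bound to an aromatic nitrogen. Cut one bond further out, the change reads 4-(trifluoromethyl)benzyl to propyl, so compound 4 is the one-carbon extension of compound 1.

The step that bears on it most directly is the reverse of the one already seen at this position, a 1.2-fold higher number from compound 1 to compound 3 (0.07 log units; within the scatter), which was within the scatter; the other two steps, which exchange the whole group on the aromatic nitrogen, were also within the scatter. For the measured compounds named here, no step in this set has moved the number beyond the scatter. The expectation for a 1.2-fold lower number from compound 3 to compound 4 (0.07 log units; within the scatter) is therefore no change beyond the scatter, with compound 4 expected near compound 1 because of 15000 nM.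

Compound 4 is estimated at 15000 nM, within a range from 7000 nM to 32000 nM.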

Compound 4, half-maximal inhibitory concentration: 9670 nM
Compound 4: the middle estimate sits 1.6-fold (0.19 log units) above what was measured; measured number inside the range.
By their numbers in this assay, from the lowest: compounds 4, 2, 1 and 3 (each within the scatter of the next).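

In this assay the new propyl member adds three comparisons on the aromatic nitrogen: against the ethyl group (a 1.6-fold lower number from compound 1 to compound 4 (0.19 log units; within the scatter)), against 4-(trifluoromethyl)benzyl (a 1.8-fold lower number from compound 3 to compound 4 (0.26 log units; within the scatter)) and against cyclopentyl (a 1.1-fold lower number from compound 2 to compound 4 (0.04 log units; within the scatter)). Neither the one-carbon extension nor the exchange of 4-(trifluoromethyl)phenyl for ethyl on the saturated chain carbon moves the number beyond the scatter, so a straight chain, a saturated ring and a benzyl group all remain indistinguishable here, and the flat picture from the first three compounds now extends to a fourth group. Nothing available on these compounds offers an explanation for this flat response.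

Still open, going by these compounds, is whether a different kind of group on the aromatic nitrogen, such as a chain ending in a tertiary amine or a carboxylic acid, or a much longer chain such as octyl, would move the number beyond the scatter. Also open, on these data alone, is whether a change on the shared core, such as a methyl ether in place of its free hydroxyl, would matter more than any exchange on the nitrogen.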